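A few compounds are considered here, and "the series" means these few. Any claim that something is new, unique, unknown or untested is made for them only; others in the source may bear on it.

Measured compounds:
compound 1 `CCCCCCCCOc1ccc2c(=O)c(Cc3c(OC(C)=O)ccc4c(C)cc(=O)oc34)c(N(CC)CC)oc2c1`: > 100000 nM
compound 2 `COc1ccc2c(=O)c(Cc3c(OC(C)=O)ccc4ccc(=O)oc34)c(N3CCCC3)oc2c1`: > 100000 nM

In an ADME assay on MT4 cells (Homo sapiens) for cytotoxicity, read by MTT assay, with a stated time of 96 h (on this read-out lower numbers stand for higher toxicity in this test and higher numbers for lower toxicity in this test), compound 1 gives > 100000 nM, which is a limit of the assay rather than a number. Compound 2 likewise gives > 100000 nM in this assay, again a limit. Compound 1 therefore stands at the limit together with the one other compound shown: the limit of > 100000 nM in this assay, at which 2 of the 2 values shown sit. Among the measured compounds shown here, no step between measured compounds differing in one place is available, so no measured step size can be quoted.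

Compound 3 `CCN(CC)c1oc2cc(OC(C)=O)ccc2c(=O)c1Cc1c(OC(C)=O)ccc2c(C)cc(=O)oc12` differs from compound 1 in one place: acetyl in place of octyl on an oxygen on an aromatic ring. No step from compound 1 to compound 3 beyond the usual scatter is expected in this assay, the reason being (the limit of > 100000 nM in this assay, at which 2 of the 2 values shown sit). Compound 3 is expected to remain at the limit as well. Compound 3 is estimated at 100000 nM in this assay, within 50000 nM to 300000 nM, which means an expected step of a number no higher from compound 1 to compound 3 (the limit leaves the size open).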

Compound 3, half-maximal cytotoxic concentration: 44000 nM
Compound 3: the middle estimate sits 2.3-fold (0.36 log units) above what was measured; the measured number lies below the stated range.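

In this assay, the change from octyloxy to acetoxy on the shared core gives an at least 2.2-fold lower number from compound 1 to compound 3 (0.35 log units; beyond the scatter), so this oxygen on an aromatic ring is a place where the choice of group can move the read-out towards higher toxicity in this test. The earlier compounds shown here could not show this, as neither gave a number. Compound 3, at 44000 nM, is the only compound shown to give a number rather than a limit: the limit of > 100000 nM in this assay, at which 2 of the 3 values shown sit.

From the compounds shown here alone, compound 1 gives > 100000 nM, a limit and not a number, and the full size of the step stays open. Also open, going by these compounds, is whether a free hydroxyl group or a butyl chain on this oxygen would stay at the limit with octyl or give a number as acetyl does.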